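Direct 4-methoxyphenyl in place of the thienylmethyl arm

A few compounds are considered here, and "the series" means these few. Any claim that something is new, unique, unknown or untested is made for them only; others in the source may bear on it.

Compound 3 `Cc1cc(Cc2cccs2)c(=O)n(CC(=O)Nc2ccc(Br)cc2)n1` is one of three compounds tested in a functional assay on HL-60 cells (Homo sapiens), read by calcium flux; on this read-out higher numbers stand for an effect only at larger amounts of compound and lower numbers for an effect already at smaller amounts. In this assay compound 3 gives only a limit, > 50000 nM. Compound 1 `Cc1cc(Cc2cccc(F)c2)c(=O)n(CC(=O)Nc2ccc(Br)cc2)n1` likewise gives only a limit in this assay, > 50000 nM. Compound 2 `Cc1cc(Cc2ccsc2)c(=O)n(CC(=O)Nc2ccc(Br)cc2)n1` also reaches only a limit in this assay, > 50000 nM. The three steps among them, a step that the two limits leave unreadable from compound 1 to compound 2, a step that the two limits leave unreadable from compound 1 to compound 3 and a step that the two limits leave unreadable from compound 2 to compound 3, are all unreadable because every value sits at the limit of > 50000 nM in this assay, at which 3 of the 3 values shown sit.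

Compound 4 `COc1ccc(-c2cc(C)nn(CC(=O)Nc3ccc(Br)cc3)c2=O)cc1` differs from compound 3 by 4-methoxyphenyl in place of (thiophen-2-yl)methyl on an aromatic carbon. Among the compounds with values here, none of the measured steps concerns this change: they only exchange one ring for another on the saturated chain carbon, and none has a readable size. Within the data shown here, there is therefore no measured step from which a direction in this assay could be taken. With all three measured compounds at the limit, compound 4 is expected to give 50000 nM, within 5000 nM to 100000 nM, most probably again only a limit. The step this implies, a number no higher from compound 3 to compound 4 (the limit leaves the size open), is an estimate without measured support.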

Compound 4, half-maximal effective concentration: > 50000 nM
Compound 4: only a limit was reported (the forecaster's own chance of this, stated with the estimate: 70%); the middle value lies on the limit itself.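

Compound 4 again gives only a limit in this assay, > 50000 nM. Its steps from compound 1, compound 2 and compound 3 cannot be read, because all values sit at the same limit: the limit of > 50000 nM in this assay, at which 4 of the 4 values shown sit.

The compounds shown leave open whether any arm on the shared core gives a readable value in this assay.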